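This account rests on a few compounds, and the source may have more. Where it says the series, first, only, none or still open, it means among the compounds named here.

Measured compounds:

- compound 1 `CN(c1ccc(Oc2ncnc3ccsc23)cc1)c1nccc(N2CCCCC2)n1`: 8240 nM
- compound 2 `CNC(=O)c1cc(Oc2ccc(Nc3nccc(N4CCCCC4)n3)cc2)ccn1`: 890 nM

Of the compounds shown here, two have been measured in a functional assay on A549 cells (Homo sapiens) for inhibition, read by MTT assay, with a stated time of 72 h; a higher number here means a weaker inhibitor, a lower number a stronger inhibitor. Compound 1 gives 8240 nM in this assay, and compound 2 gives 890 nM in this assay. Among the compounds with values here, of the two, compound 2 stands at the lower number, the stronger inhibitor, and its gap to compound 1 lies beyond the scatter; no single-change step links the two, so the gap is only what the two values show.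

The next compound is compound 3 `c1cc(N2CCCCC2)nc(Nc2ccc(Oc3ncnc4ccsc34)cc2)n1`, which follows from compound 2 by one change: a group of 9 heavy atoms (6 carbon, 2 nitrogen, 1 sulfur; one five-membered aromatic ring with 1 hetero atom, one six-membered aromatic ring with 2 hetero atoms) in place of a group of 10 heavy atoms (7 carbon, 2 nitrogen, 1 oxygen; one six-membered aromatic ring with 1 hetero atom), on an oxygen on an aromatic ring. The group that enters is the same two-ring group that compound 1 carries on its oxygen, while the linker between the two aromatic rings stays as in compound 2, with its hydrogen.

Within the data shown here, no measured step of this kind is available. The expectation is a moderate rise in the number from compound 2, written as a 2.8-fold higher number from compound 2 to compound 3 (0.45 log units; beyond the scatter), because compound 1, which also carries this group, gives 8240 nM. Compound 3 is estimated at 2500 nM, within a range from 600 nM to 10000 nM.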

Compound 3, half-maximal inhibitory concentration: 7800 nM
Beside the measured number, compound 3's estimate is 3.1-fold (0.49 log units) below it; the measured number falls inside the stated range.
By their numbers in this assay, from the lowest: compound 2; then compounds 3 and 1 (each within the scatter of the next).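

Compound 3 splits the two differences between compound 1 and compound 2, so each can now be read alone. On the oxygen on an aromatic ring, the two-ring group in place of 2-(methylcarbamoyl)pyridin-4-yl gives an 8.8-fold higher number from compound 2 to compound 3 (0.94 log units; beyond the scatter) in this assay, so with this linker hydrogen the change of group carries a clear loss of inhibition. Hydrogen in place of methyl on the nitrogen gives a 1.1-fold lower number from compound 1 to compound 3 (0.02 log units; within the scatter), so with the two-ring group on the oxygen, that methyl makes no difference that can be told from the scatter.

Going by these compounds, whether the methyl would count for as little with 2-(methylcarbamoyl)pyridin-4-yl on the oxygen remains open. Also open is which part of that group matters, a question that a plain pyridine ring, or a primary amide or carboxylic acid in place of the methylcarbamoyl, could help to settle, and no measurement at hand offers a reason for either step.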